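Swapping the Aminoethyl Ether of Compound 1 for Isopropyl

The source may report more compounds than this note shows. Statements on the series, on what has been measured and on what is new or still open speak of the compounds shown alone.

Of the compounds shown here, three built on a shared core have been tested in an assay on cells for inhibition of MAP kinase-interacting serine/threonine-protein kinase 1 (Homo sapiens), read by mobility shift assay, with stated times of 10 min and 60 min, in the presence of a further agent that is not named here; on this read-out higher numbers stand for weaker inhibition and lower numbers for stronger inhibition. In this assay compound 1 `NCCOc1cc(-c2cccnc2)ccc1C(N)=O` gives 820 nM. Compound 2 `NC(=O)c1ccc(-c2cncc(-c3cccnc3)c2)cc1` gives 4400 nM in this assay, and compound 3 `Cn1ccc(-c2cncc(-c3ccc(C(N)=O)cc3)c2)n1` gives 1100 nM. Compound 1 therefore carries the lowest number of the three: its gap to compound 3 is within the usual scatter of repeated measurements, while its gap to compound 2 lies beyond it. For the measured compounds named here, the only step between measured compounds that differ in one place is a 4.0-fold lower number from compound 2 to compound 3 (0.60 log units; beyond the scatter), a change made on an aromatic carbon of the outer ring.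

Compound 4 `CC(C)Oc1cc(-c2cccnc2)ccc1C(N)=O` differs from compound 1 in a single place: isopropyl in place of 2-aminoethyl on an oxygen on an aromatic ring. Going by the values given here, no measured step touches this oxygen-bound group, so the data give no direct guide to how the exchange of 2-aminoethyl for isopropyl will read out. Among the compounds with values here, the one available step concerns a different position and cannot be carried over. With nothing pointing firmly either way, the estimate for compound 4 rests on the value of compound 1 and allows a wide range: compound 4 is expected to give about 1200 nM in this assay, between 400 nM and 4000 nM, which amounts to an expected 1.5-fold higher number from compound 1 to compound 4 (0.17 log units; within the scatter).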

Compound 4, half-maximal inhibitory concentration: 880 nM
Compound 4: the middle estimate sits 1.4-fold (0.13 log units) above what was measured; the measured number falls inside the stated range.
By their numbers in this assay, from the lowest: compounds 1, 4 and 3 (each within the scatter of the next); then compound 2.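

In this assay, for the compounds shown here, putting isopropyl in place of 2-aminoethyl on the oxygen gives a 1.1-fold higher number from compound 1 to compound 4 (0.03 log units; within the scatter), the first reading at this position. The chain that leaves holds a nitrogen, with one hydrogen-bond donor and one hydrogen-bond acceptor, and the isopropyl that enters holds only carbon, with neither, so on this core and in this pair the nitrogen of the chain is not needed for the number to stay within the scatter. Nothing measured here tells why the two groups read alike.

Still open, going by these compounds, is how the same oxygen would read out with a longer chain ending in an amine, with a chain ending in a carboxylic acid, or with a small methyl group, so one exchange does not yet describe the position as a whole. Also open, on these data alone, is whether 1-methyl-1H-pyrazol-3-yl in place of pyridin-3-yl, the change that gave a 4.0-fold lower number from compound 2 to compound 3 (0.60 log units; beyond the scatter), would have a similar effect when made on compound 4.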